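This account rests on a few compounds, and the source may have more. Where it says the series, first, only, none or still open, it means among the compounds named here.

Measured compounds:
compound 1 `O=C(NO)c1cccc(OCc2ccc(-c3ccc(Cl)cc3)cc2)c1`, 360 nM
compound 2 `O=C(NO)c1cc(OCc2ccc(-c3ccccc3)cc2)no1`, 4090 nM

In an assay on isolated protein for inhibition of sphingomyelin phosphodiesterase (Homo sapiens), read by fluorescence, with a stated time of 30 min (a lower number here means a stronger inhibitor, a higher number a weaker inhibitor), compound 2 gives 4090 nM, the higher of the two numbers shown, and compound 1 gives 360 nM, a lower number whose gap from compound 2 lies beyond the usual scatter. Compound 3 `O=C(NO)c1cc(OCc2ccc(-c3ccc(Cl)cc3)cc2)no1` carries the change (chloro in place of hydrogen on an aromatic carbon), chloro in place of hydrogen on an aromatic carbon. For the measured compounds named here, no measured pair shows this change on this core, so the expected step is modest, with a slight lean toward a lower number. On that basis compound 3 is estimated at 2000 nM, within 700 nM to 6000 nM, a step of a 2.0-fold lower number from compound 2 to compound 3 (0.31 log units; beyond the scatter) from compound 2.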

Compound 3, half-maximal inhibitory concentration: 3370 nM
The estimate for compound 3 lay 1.7-fold (0.23 log units) below the measured number, within the range that was stated.
By their numbers in this assay, from the lowest: compound 1; then compounds 3 and 2 (each within the scatter of the next).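

The change from phenyl to 4-chlorophenyl gives, in this assay, a 1.2-fold lower number from compound 2 to compound 3 (0.08 log units; within the scatter). For the compounds shown here, this is the first reading of chloro in place of hydrogen at this place, para to a large group, and on this core the swap does not separate the two numbers beyond the scatter. Nothing at hand bears on why this is so. As far as these compounds go, what stays open is whether a methoxy group, an amine or a carboxylic acid at the same place would move the number on this core. Also open, from the compounds shown here alone, is whether the same change would read differently on the core of compound 1.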